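Cytotoxicity notes: fluoro to hydrogen on the aryl ring

The source may hold more compounds than are shown below. What is called first, only, known or untested is meant among the compounds shown, and "the series" means these compounds.

The series is followed in an ADME assay on cells (Homo sapiens) for cytotoxicity; a lower number here means that less compound is tolerated, a higher number that more compound is tolerated. Compound 1 `NC(=O)c1nc(C#Cc2ccc(F)cc2)n(COCCO)n1` gives > 160000 nM there, which is a limit of the assay and not a number. Compound 2 `NC(=O)c1nc(C#Cc2ccc(C(F)(F)F)cc2)n([C@@H]2O[C@H](CO)[C@@H](O)[C@H]2O)n1` likewise gives only a limit, > 120000 nM. Compound 3 `COC(=O)c1nc(C#CC2(O)CCCC2)n([C@@H]2O[C@H](COC(C)=O)[C@@H](OC(C)=O)[C@H]2OC(C)=O)n1` also sits at a limit, > 105000 nM. Since all three values shown are limits, compound 1 cannot be ranked against the others; no half-maximal cytotoxic concentration was reached for any of them. Compound 4 `NC(=O)c1nc(C#Cc2ccccc2)n(COCCO)n1` differs from compound 1 by hydrogen in place of fluoro on an aromatic carbon. Among the measured compounds shown here, no step between measured compounds is available for comparison. The step of a number no higher from compound 1 to compound 4 (the limit leaves the size open) is expected to be none beyond the scatter. Compound 4 is estimated at 160000 nM, with a range from 80000 nM to 320000 nM, most likely again reported only as a limit.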

Compound 4, half-maximal cytotoxic concentration: > 170000 nM
Compound 4 was reported as a limit; the forecaster's own chance of this, stated with the estimate: 85%; middle value at least 1.0-fold (0.02 log units) from the limit.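

Compound 1 and compound 4 are both reported only as limits, and the step from 4-fluorophenyl to phenyl cannot be read. The compounds shown leave open the half-maximal cytotoxic concentration of each, and whether fluoro makes any difference.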